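Swapping the aryl group on the core nitrogen

A few compounds are considered here, and "the series" means these few. Any claim that something is new, unique, unknown or untested is made for them only; others in the source may bear on it.

Of the compounds shown here, three sharing one core have been tested in a functional assay on HT-29 cells (Homo sapiens) for antiproliferative activity, read by MTT assay, with a stated time of 72 h; a higher number here means a weaker inhibitor, a lower number a stronger inhibitor. Compound 1 `O=C(Nc1ccc(Oc2ccnc3[nH]ccc23)cc1)c1cc2cccnc2n(-c2ccc(Br)cc2)c1=O` gives 270 nM, compound 2 `COc1ccc(-n2c(=O)c(C(=O)Nc3ccc(Oc4ccnc5[nH]ccc45)cc3)cc3cccnc32)cc1` gives 1260 nM, and compound 3 `O=C(Nc1ccc(Oc2ccnc3[nH]ccc23)cc1)c1cc2cccnc2n(-c2ccc(F)c(Cl)c2)c1=O` gives 560 nM, the second highest of the three. The step of a 2.1-fold higher number from compound 1 to compound 3 (0.32 log units; beyond the scatter) and the step of a 2.3-fold lower number from compound 2 to compound 3 (0.35 log units; beyond the scatter) show that changing this ring shifts the result only modestly. Compound 4 `O=C(Nc1ccc(Oc2ccnc3[nH]ccc23)cc1)c1cc2cccnc2n(-c2ccc(Br)cc2F)c1=O` differs from compound 3 by 4-bromo-2-fluorophenyl in place of 3-chloro-4-fluorophenyl on an aromatic nitrogen. Since compound 4 carries the bromo group of compound 1, which gave 270 nM, a modest move back toward that number is expected, a 1.6-fold lower number from compound 3 to compound 4 (0.20 log units; within the scatter), giving an estimated 350 nM for compound 4, likely between 150 nM and 900 nM.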

Compound 4, half-maximal inhibitory concentration: 2360 nM
Compound 4: middle estimate off by 6.7-fold (0.83 log units), on the low side, outside the stated range (above it).
By their numbers in this assay, from the lowest: compound 1; then compound 3; then compounds 2 and 4 (each within the scatter of the next).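

A single added fluoro matters most here: in this assay the move from 4-bromophenyl to 4-bromo-2-fluorophenyl gives an 8.7-fold higher number from compound 1 to compound 4 (0.94 log units; beyond the scatter) and so the bromo group alone does not secure a low number. The same ring also gives a 4.2-fold higher number from compound 3 to compound 4 (0.62 log units; beyond the scatter) while a 1.9-fold higher number from compound 2 to compound 4 (0.27 log units; within the scatter) leaves it level with 4-methoxyphenyl in this assay. Nothing available here explains the effect of this fluoro. From the compounds shown here alone, whether a methyl group or chlorine in place of that fluoro would raise the number as much remains open, as does the effect of an amine on this ring.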